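Same benzyl swap on an acid and an ester

A few compounds are considered here, and "the series" means these few. Any claim that something is new, unique, unknown or untested is made for them only; others in the source may bear on it.

Compound 1, `COC(=O)[C@H](CCSC)NC(=O)c1ccc(NCc2cncn2Cc2cccc(C#N)c2)cc1-c1ccccc1`, is an ester built on a shared core. In a functional assay on NIH3T3 cells (Mus musculus) (a lower number here means that less compound is needed, a higher number that more compound is needed for the effect), compound 1 gives only a limit, > 10 uM, not a number. Compound 2, `COC(=O)[C@H](CCSC)NC(=O)c1ccc(NCc2cncn2Cc2ccccc2C)cc1-c1ccccc1`, differs from compound 1 by 2-methylphenyl in place of 3-cyanophenyl on a saturated chain carbon bound to an aromatic nitrogen. In this assay compound 2 also reaches only the limit, > 10 uM. The step that the two limits leave unreadable from compound 1 to compound 2 therefore cannot be sized. Compound 3, `CSCC[C@H](NC(=O)c1ccc(NCc2cncn2Cc2cccc(C#N)c2)cc1-c1ccccc1)C(=O)O`, differs from compound 1 by hydrogen in place of methyl on an oxygen next to a carbonyl group. In this assay compound 3 gives the limit > 10 uM as well, so the step that the two limits leave unreadable from compound 1 to compound 3 is likewise not readable. All three measured values sit at the limit of > 10 uM in this assay, at which 3 of the 3 values shown sit.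

Compound 4, `CSCC[C@H](NC(=O)c1ccc(NCc2cncn2Cc2ccccc2C)cc1-c1ccccc1)C(=O)O`, has not yet been measured. It differs from compound 3 by 2-methylphenyl in place of 3-cyanophenyl on a saturated chain carbon bound to an aromatic nitrogen, which is the same change made from compound 1 to compound 2, on the same kind of place. The cores of compound 3 and compound 4 differ from those of compound 1 and compound 2 in the way described above. Since the step from compound 1 to compound 2 left both values at the limit, the step from compound 3 to compound 4 is expected to be a step that the limit leaves unreadable from compound 3 to compound 4, meaning no readable change. Compound 4 is therefore estimated to give about 20 uM in this assay, most likely reported again only as a limit, with a plausible range from 10 uM to 60 uM.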

Compound 4, concentration for half-maximal effect: > 10 uM
Compound 4 gave a limit, no number (the forecaster's own chance of this, stated with the estimate: 85%); the middle value lies beyond the limit too.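

No new step can be read from compound 4: its comparisons with compound 2 and compound 3 both end in limits rather than numbers, as do all the results in this assay: the limit of > 10 uM in this assay, at which 4 of the 4 values shown sit.

The compounds shown leave open what number each of the four would give, and so whether going from 3-cyanobenzyl to 2-methylbenzyl, or from ester to acid, changes the concentration needed at all.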